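The compounds below may be only part of what the source reports. "The series", "measured", "known", "first", "only" and "open" are said of these compounds alone.

In an assay on frontal cortex for displacement of a labelled ligand from corticotropin-releasing factor receptor 1 (Rattus norvegicus), with a stated time of 2 h (a lower number here means a stronger inhibitor, a higher number a weaker inhibitor), compound 2 `CCCNC(=O)OC[C@H](C1CC1)n1cc(Cl)nc(Nc2cc(C)c(OC)nc2C)c1=O` gives 10 nM. For the measured compounds named here, of the two numbers measured so far it is the smaller, though compound 1 `CCNC(=O)OC[C@H](C1CC1)n1cc(Cl)nc(Nc2cc(C)c(OC)nc2C)c1=O` gives 14 nM and the step of a 1.4-fold lower number from compound 1 to compound 2 (0.15 log units; within the scatter) lies within the scatter. Compound 3 `COc1nc(C)c(Nc2nc(Cl)cn([C@H](COc3cccnc3)C3CC3)c2=O)cc1C` differs from compound 2 by pyridin-3-yl in place of propylcarbamoyl on an oxygen on a saturated carbon. Going by the values given here, the only measured step, the lengthening of the chain on the amide-type nitrogen, does not bear on exchanging the whole carbamate group for an aromatic ring, so no direction is indicated. The expected step of a 1.5-fold higher number from compound 2 to compound 3 (0.18 log units; within the scatter) is therefore set near zero, and compound 3 is estimated at 15 nM, within 4 nM to 60 nM.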

Compound 3, half-maximal inhibitory concentration: 6.7 nM
Compound 3: middle estimate off by 2.2-fold (0.35 log units), on the high side; the measured number falls inside the stated range.
By their numbers in this assay, from the lowest: compounds 3, 2 and 1 (each within the scatter of the next, the first and the last beyond it).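

On the oxygen on a saturated carbon, an aromatic ring can stand in place of a carbamoyl group with no loss in this assay. Pyridin-3-yl in place of propylcarbamoyl gives no clear change (a 1.5-fold lower number from compound 2 to compound 3 (0.17 log units; within the scatter)), while in place of ethylcarbamoyl it gives a modest gain (a 2.1-fold lower number from compound 1 to compound 3 (0.32 log units; beyond the scatter)). Nothing measured here offers a reason for either step.

On these data alone, whether the ring nitrogen matters remains open, and a plain phenyl ring would test that. So does its location, which pyridin-2-yl or pyridin-4-yl would test.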